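Compound 2 to compound 3 in MOLT-4 cells

A few compounds are considered here, and "the series" means these few. Any claim that something is new, unique, unknown or untested is made for them only; others in the source may bear on it.

Compound 1 `Nc1cc(N)c2nc(-c3ccccc3)c(Oc3ccc(Cl)c(Cl)c3)nc2c1`: < 100000 nM
Compound 2 `COc1ccc(CNc2nc3cc(N)cc(N)c3nc2-c2ccccc2)cc1OC`: < 100000 nM

In a functional assay on MOLT-4 cells (Homo sapiens) for inhibition, read by sulforhodamine B assay, with a stated time of 48 h (a lower number here means that less compound is tolerated, a higher number that more compound is tolerated), compound 1 gives < 100000 nM, which is a limit of the assay and not a number. Compound 2 gives < 100000 nM in this assay, again a limit rather than a number. Compound 2 therefore stands at the same place as the only other compound shown, since (the limit of < 100000 nM in this assay, at which 2 of the 2 values shown sit), and nothing in the numbers sets the two apart. The change that leads to compound 3 `Nc1cc(N)c2nc(-c3ccccc3)c(NCc3ccc(F)cc3)nc2c1` is 4-fluorophenyl in place of 3,4-dimethoxyphenyl on a saturated chain carbon bound to a nitrogen on an aromatic ring; the rest of the structure is kept. For the measured compounds named here, no step between two measured compounds is available to guide the size or direction of this change, and the two values at hand are limits only. The step from compound 2 to compound 3 is expected to be a step that the limit leaves unreadable from compound 2 to compound 3, a change no larger than the scatter of this assay would hide, and quite possibly a limit again. Compound 3 is estimated at 40000 nM in this assay, within a range of 8000 nM to 100000 nM.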

Compound 3, concentration lethal to 50% of the cells: < 100000 nM
Compound 3 was reported as a limit; the forecaster's own chance of this, stated with the estimate: 60%; the middle value does not contradict the limit.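

Compound 3 gives < 100000 nM in this assay as a limit of the assay and not a number. For the compounds shown here, no step from compound 1 or compound 2 to compound 3 can be read, because all three values sit at one limit: the limit of < 100000 nM in this assay, at which 3 of the 3 values shown sit. The compounds shown leave open how far the three lie apart, and whether 4-fluorophenyl in place of 3,4-dimethoxyphenyl changes the value at all.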